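A side-chain swap close to the assay limit

The source may report more compounds than this note shows. Statements on the series, on what has been measured and on what is new or still open speak of the compounds shown alone.

In a functional assay on KB cells (Homo sapiens) for antiproliferative activity, read by MTT assay, with a stated time of 48 h (a lower number here means a stronger inhibitor, a higher number a weaker inhibitor), compound 1 `Cn1cc(C2=C(c3nn(CCCn4cncn4)c4ncccc34)C(=O)NC2=O)c2ccccc21` gives > 100000 nM, which is a limit and not a number. Compound 2 `CN(C)CCCn1nc(C2=C(c3cn(C)c4ccccc34)C(=O)NC2=O)c2cccnc21` gives > 100000 nM, which is also only a limit. Going by the values given here, compound 3 `Cn1cc(C2=C(c3nn(CCCN4CCCCC4)c4ncccc34)C(=O)NC2=O)c2ccccc21` gives 98000 nM, the only actual number of the three, so it offers the sole firm starting point.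

Compound 4 `Cn1cc(C2=C(c3nn(CCCCn4ccnc4)c4ncccc34)C(=O)NC2=O)c2ccccc21` changes the end of the same chain: (1H-imidazol-1-yl)methyl in place of piperidin-1-yl on a saturated chain carbon, three bonds along the chain from an aromatic nitrogen. Cut one bond further out, 3-(piperidin-1-yl)propyl gives way to 4-(1H-imidazol-1-yl)butyl.

Among the compounds with values here, earlier changes at this place offer the only guide. They are an at least 1.0-fold lower number from compound 1 to compound 3 (0.00 log units; that floor lies within the scatter), an at least 1.0-fold lower number from compound 2 to compound 3 (0.00 log units; that floor lies within the scatter) and a step that the two limits leave unreadable from compound 1 to compound 2. None of these shows a readable change beyond the scatter, so no clear shift is expected in this assay here. The expected step is a 1.0-fold higher number from compound 3 to compound 4 (0.01 log units; within the scatter).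

Compound 4 is estimated at 100000 nM, with an expected range from 40000 nM to 150000 nM. The assay may well report only a limit for it.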

Compound 4, half-maximal inhibitory concentration: > 100000 nM
Compound 4: a limit, no number; the forecaster's own chance of this, stated with the estimate: 65%; the middle value sits exactly at the limit.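

In this assay, the value of compound 4 is a limit and not a number, so the move from piperidin-1-yl to (1H-imidazol-1-yl)methyl can only be stated as an at least 1.0-fold higher number from compound 3 to compound 4 (0.00 log units; that floor lies within the scatter). The steps to compound 4 from compound 1 and compound 2 cannot be read, as both ends of each are limits. With an aromatic five-membered ring now at the chain end as well, this position has still given no step readable beyond the scatter, and the values gather at one point: the limit of > 100000 nM in this assay, at which 3 of the 4 values shown sit.

The compounds shown do not separate the change of ring from the longer chain, which 3-(1H-imidazol-1-yl)propyl or 4-(piperidin-1-yl)butyl on the same core would do. Also open, as far as these compounds go, is whether a morpholine ring or a primary amine at the chain end would give a clearly lower number in this assay.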